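The source may report more compounds than this note shows. Statements on the series, on what has been measured and on what is new or still open speak of the compounds shown alone.

Compound 1 `CCOCCOC(=O)C(=O)Nc1nc(-c2cc(C)on2)cs1` and compound 2 `CCOCCOC(=O)C(=O)Nc1nc(-c2cc(CO)on2)cs1` share the core of compound 1; compound 3 `Cc1cc(-c2csc(NC(=O)C(=O)O)n2)on1` and compound 4 `O=C(O)C(=O)Nc1nc(-c2cc(CO)no2)cs1` share the core of compound 3. How the two cores differ is not broken down here. In a functional assay on the whole organism with Rattus norvegicus as the target (a lower number here means that less compound is needed, a higher number that more compound is needed for the effect), compound 1 gives 2 mg/kg, compound 2 gives 14 mg/kg and compound 3 gives 6 mg/kg. The change from compound 1 to compound 2 is hydroxy in place of hydrogen on a saturated chain carbon bound to an aromatic carbon. It made a 7.0-fold higher number from compound 1 to compound 2 (0.85 log units; beyond the scatter). The change from compound 3 to compound 4 is hydroxy in place of hydrogen on a saturated chain carbon bound to an aromatic carbon, at the same place, so it is taken as the same change. Compound 4 has not yet been measured in this assay. Going by the values given here, for compound 4 the expected step is a 6.7-fold higher number from compound 3 to compound 4 (0.82 log units; beyond the scatter), set to match the earlier one because a 7.0-fold higher number from compound 1 to compound 2 (0.85 log units; beyond the scatter) is the only measured instance of this change. Compound 4 is expected to give about 40 mg/kg, between 15 mg/kg and 110 mg/kg.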

Compound 4, dose for half-maximal effect: 0.7 mg/kg
Compound 4: middle estimate off by 57-fold (1.76 log units), on the high side; measured number outside the range, below it.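

In this assay, methyl to hydroxymethyl gave an 8.6-fold lower number from compound 3 to compound 4 (0.93 log units; beyond the scatter), so the step measured on the core of compound 1 does not carry over to the core of compound 3 in size or direction: the same change on two cores in this assay, a 7.0-fold higher number (0.85 log units; beyond the scatter) from compound 1 to compound 2 and an 8.6-fold lower number (0.93 log units; beyond the scatter) from compound 3 to compound 4, 60-fold (1.78 log units) apart, beyond the scatter of two such steps

On these two cores, the change has to be read separately, and a step from one core gives no guide to the other. The two pairs do not show which difference between the cores goes with the reversal, and with one pair per core, neither step is shown to hold beyond its own pair.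

Open, from the compounds shown here alone, is how an amine or a longer chain in place of the hydroxy would behave on either core.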